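The source may report more compounds than this note shows. Statements on the series, on what has been measured and on what is new or still open speak of the compounds shown alone.

Compound 3 `O=C(O)c1cccc(-c2ccc(/C=C3\S/C(=N\c4ccccc4)N(c4cccnc4Cl)C3=O)s2)c1` sits in an ADME assay on Vero cells (Chlorocebus sabaeus) for cytotoxicity (a higher number here means that more compound is tolerated, a lower number that less compound is tolerated), at > 200000 nM, which is a limit of the assay rather than a number. Compound 1 `O=C(O)c1cccc(-c2ccc(/C=C3\S/C(=N\c4ccccc4)N(c4ccc(Cl)cc4)C3=O)s2)c1` likewise gives in this assay > 200000 nM, again only a limit. Compound 2 `O=C(O)c1cccc(-c2ccc(/C=C3\S/C(=N\c4ccccc4)N(c4ccc(F)cn4)C3=O)s2)c1` gives in this assay > 200000 nM, a limit as well. The steps among these three, a step that the two limits leave unreadable from compound 1 to compound 2, a step that the two limits leave unreadable from compound 1 to compound 3 and a step that the two limits leave unreadable from compound 2 to compound 3, therefore carry no readable size, because the limit of > 200000 nM in this assay, at which 3 of the 3 values shown sit, sets the ceiling under which nothing in this set has been distinguished.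

Compound 4 `O=C(O)c1cccc(-c2ccc(/C=C3\S/C(=N\c4ccccc4)N(c4cccnc4[N+](=O)[O-])C3=O)s2)c1` differs from compound 3 by nitro in place of chloro on an aromatic carbon. No measured step in this assay speaks to the nitro group, and no step here has shown any compound falling short of the ceiling. The step from compound 3 to compound 4 is therefore expected to read a number no higher from compound 3 to compound 4 (the limit leaves the size open), nothing beyond the scatter. Compound 4 is expected in this assay at 200000 nM, within a range from 100000 nM to 400000 nM, most likely reported once more as a limit.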

Compound 4, half-maximal cytotoxic concentration: > 200000 nM
Compound 4: a limit, no number; the forecaster's own chance of this, stated with the estimate: 85%; the middle value sits exactly at the limit.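

In this assay compound 4 gives > 200000 nM, again a limit, so its steps from compound 1, compound 2 and compound 3 cannot be read: the limit of > 200000 nM in this assay, at which 4 of the 4 values shown sit.

The compounds shown leave open how far apart these four lie in this assay, and whether any group on the amide-type nitrogen would bring a compound under that limit.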